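The source may report more compounds than this note shows. Statements on the series, on what has been measured and on what is new or still open speak of the compounds shown alone.

Of the compounds shown here, three have so far been measured in a functional assay on A549 cells (Homo sapiens) for antiproliferative activity, read by sulforhodamine B assay, with a stated time of 48 h (a higher number here means a weaker inhibitor, a lower number a stronger inhibitor), for their half-maximal inhibitory concentration. Compound 1 (`COc1cc(OC)c2sc(-c3ccc(N/C=C\C(=O)c4ccc(OC)c(O)c4)c(C)c3)nc2c1`) reads 14300 nM while compound 2 (`COc1cc(OC)c2sc(-c3ccc(N/C=C\C(=O)c4ccc(OC)c(O)c4)cc3)nc2c1`) reads 10600 nM and compound 3 (`COc1ccc(C(=O)/C=C\Nc2ccc(-c3nc4cc(OC)c(OC)c(OC)c4s3)cc2)cc1O`) reads 23000 nM on the same scale. Compound 2 sits at the low end of this small set, a place it shares within the scatter with compound 1. The measured steps are a 1.3-fold lower number from compound 1 to compound 2 (0.13 log units; within the scatter) and a 2.2-fold higher number from compound 2 to compound 3 (0.34 log units; beyond the scatter) in this series.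

Compound 4 (`COc1cc(OC)c2sc(-c3ccc(N/C=C\C(=O)c4cc(OC)c(OC)c(OC)c4)cc3)nc2c1`) keeps the core of compound 2 but carries 3,4,5-trimethoxyphenyl in place of 3-hydroxy-4-methoxyphenyl on a carbonyl carbon. Among the measured compounds shown here, no measured step touches that side of the molecule, so the evidence is indirect. The closest guide is compound 3, which also gains a methoxy group, though on the core, with a 2.2-fold higher number from compound 2 to compound 3 (0.34 log units; beyond the scatter) as its modest result. A small upward step in this assay is therefore expected, close to the scatter. The estimate amounts to an expected 1.4-fold higher number from compound 2 to compound 4 (0.15 log units; within the scatter) in this series. For compound 4 the estimated value is 15000 nM with an expected range from 5500 nM to 40000 nM in this assay.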

Compound 4, half-maximal inhibitory concentration: 21800 nM
Beside the measured number, compound 4's estimate is 1.5-fold (0.16 log units) below it; measured number inside the range.
By their numbers in this assay, from the lowest: compounds 2, 1, 4 and 3 (each within the scatter of the next, the first and the last beyond it).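

In this assay, among the compounds shown here, putting 3,4,5-trimethoxyphenyl in place of 3-hydroxy-4-methoxyphenyl on the carbonyl carbon gives a 2.1-fold higher number from compound 2 to compound 4 (0.31 log units; beyond the scatter), the first measured step on that side of the molecule. It shows that this position is not indifferent to the change of aryl group, although the step is modest and this single swap changes more than one feature at once: the entering group has one more methoxy-bearing oxygen count in its total and lacks the hydroxy group. No measured evidence on the compounds explains this step.

The compounds shown cannot separate losing the hydroxy group from gaining methoxy groups. As far as these compounds go, whether a 3,4-dimethoxyphenyl group, or an amine or a carboxylic acid on the aryl ring at this carbonyl carbon, would read closer to compound 2 remains open.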